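Branching the Chain on the Aromatic Nitrogen

A few compounds are considered here, and "the series" means these few. Any claim that something is new, unique, unknown or untested is made for them only; others in the source may bear on it.

Measured compounds:
compound 1, `CCCCCn1ccc2cc(/C(C)=C/C(=O)Nc3ccccc3OCCCC(=O)O)ccc21`, 23 nM
compound 2, `CCCC(C)n1ccc2cc(/C(C)=C/C(=O)Nc3ccccc3OCCCC(=O)O)ccc21`, 7.8 nM
compound 3, `CCCC(C(C)C)n1ccc2cc(/C(C)=C/C(=O)Nc3ccccc3OCCCC(=O)O)ccc21`, 7.2 nM

In an assay on Prostate gland for inhibition of steroid 5-alpha-reductase (Rattus norvegicus) (a lower number here means a stronger inhibitor, a higher number a weaker inhibitor), compound 1 gives the highest of the three numbers, so it is the weakest inhibitor here. Compound 4, `C/C(=C\C(=O)Nc1ccccc1OCCCC(=O)O)c1ccc2c(ccn2C(C(C)C)C(C)C)c1`, is not yet measured. It differs from compound 1 in one place: 1-isopropyl-2-methylpropyl in place of pentyl on an aromatic nitrogen. For the measured compounds named here, two measured steps bear on this change. Both replace the pentyl chain with a branched chain on the same aromatic nitrogen, and both lower the number by a modest amount: a 2.9-fold lower number from compound 1 to compound 2 (0.47 log units; beyond the scatter) and a 3.2-fold lower number from compound 1 to compound 3 (0.50 log units; beyond the scatter). Going from the smaller branch to the larger one changes little: a 1.1-fold lower number from compound 2 to compound 3 (0.03 log units; within the scatter). The step to compound 4 adds a branch of the same kind, now with two isopropyl arms, so a modest lowering beyond the scatter is expected, and no further gain from the extra bulk is assumed. For compound 4 the expected step is a 3.1-fold lower number from compound 1 to compound 4 (0.49 log units; beyond the scatter). Compound 4 is therefore estimated at 7.5 nM, in a range from 3 nM to 20 nM.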

Compound 4, half-maximal inhibitory concentration: 14 nM
For compound 4 the middle estimate is 1.9-fold (0.27 log units) below the measured one; measured number inside the range.
By their numbers in this assay, from the lowest: compounds 3, 2, 4 and 1 (each within the scatter of the next, the first and the last beyond it).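

In this assay, 1-isopropyl-2-methylpropyl in place of pentyl on the aromatic nitrogen gives a 1.6-fold lower number from compound 1 to compound 4 (0.22 log units; within the scatter), so unlike the two earlier branched chains, this one does not clearly separate from the straight chain. Nor does compound 4 separate from those branched compounds, with a 1.9-fold higher number from compound 3 to compound 4 (0.29 log units; within the scatter) and a 1.8-fold higher number from compound 2 to compound 4 (0.25 log units; within the scatter), so branching on this nitrogen does not bring a step beyond the scatter in every case, and compound 4 cannot be ranked against any of the other three. No measurement at hand explains this result.

From the compounds shown here alone, the effect of a longer chain such as hexyl on this aromatic nitrogen remains open. So does that of a chain carrying an amine.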